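Working notes: compound 3 and its expected value

This account rests on a few compounds, and the source may have more. Where it says the series, first, only, none or still open, it means among the compounds named here.

Measured so far in a functional assay on P388 cells (Mus musculus) for cytotoxicity, read by MTT assay, with a stated time of 72 h; a higher number here means a weaker inhibitor, a lower number a stronger inhibitor:
compound 1 `COc1ccc(/C=N/c2c(C)n(C)n(-c3ccccc3)c2=O)cc1`: compound 1 gives 186000000 nM
compound 2 `Cc1c(/N=C/c2ccc(O)cc2)c(=O)n(-c2ccccc2)n1C`: compound 2 gives 537000000 nM

Within the data shown here, compound 2 stands with the higher of the two numbers in this assay; the one step known, a 2.9-fold higher number from compound 1 to compound 2 (0.46 log units; beyond the scatter), separates it from compound 1. Compound 3 `Cc1c(/N=C/c2cccc(Cl)c2)c(=O)n(-c2ccccc2)n1C` differs from compound 2 by 3-chlorophenyl in place of 4-hydroxyphenyl on a carbon with a double bond to nitrogen. Among the measured compounds shown here, the only measured step touched the same hydroxyl, and it raised the number modestly when the methyl was removed; removing the hydroxyl altogether, with chlorine entering elsewhere on the ring, has no direct precedent here. Compound 3 is therefore expected to move back toward the value of compound 1, a step of a 2.7-fold lower number from compound 2 to compound 3 (0.43 log units; beyond the scatter), with the chlorine leaving the direction uncertain. The estimate for compound 3 is 200000000 nM, within 60000000 nM to 700000000 nM.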

Compound 3, half-maximal inhibitory concentration: 550000000 nM
Beside the measured number, compound 3's estimate is 2.8-fold (0.44 log units) below it; measured number inside the range.
By their numbers in this assay, from the lowest: compound 1; then compounds 2 and 3 (each within the scatter of the next).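

In this assay, 3-chlorophenyl in place of 4-hydroxyphenyl on the carbon with a double bond to nitrogen gives no readable shift (a 1.0-fold higher number from compound 2 to compound 3 (0.01 log units; within the scatter)), even though the hydrogen-bond donor and acceptor counted on 4-hydroxyphenyl are gone. Against 4-methoxyphenyl, the same group gives a step beyond the scatter (a 3.0-fold higher number from compound 1 to compound 3 (0.47 log units; beyond the scatter)), so among these three compounds only compound 1 stands apart.

Still open, as far as these compounds go, is how an amine, a carboxylic acid or a longer ether chain on this ring would read. No supporting data explain either step.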